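The compounds below may be only part of what the source reports. "The series", "measured", "known", "first", "only" and "open" are said of these compounds alone.

Measured in a functional assay on the whole organism with Rattus norvegicus as the target; a higher number here means that more compound is needed for the effect, a lower number that less compound is needed:
Compound 1 `COc1nc(C)cc(SC)c1NC(=O)N(Cc1ccc(Oc2ccc(F)cc2)cc1)C1CCCCCC1`: < 0.032 mg/kg (a limit)
Compound 2 `CSc1cc(C)nc(Cl)c1NC(=O)N(Cc1ccc(Oc2ccc(F)cc2)cc1)C1CCCCCC1`: 0.022 mg/kg
Compound 3 `CSc1cc(C)nc(S(C)(=O)=O)c1NC(=O)N(Cc1ccc(Oc2ccc(F)cc2)cc1)C1CCCCCC1`: > 0.1 mg/kg (a limit)

Going by the values given here, compound 2 holds the only exact number of the three; the other two values are limits. Compound 4 `Cc1ccc(NC(=O)N(Cc2ccc(Oc3ccc(F)cc3)cc2)C2CCCCCC2)c(Cl)n1` differs from compound 2 by hydrogen in place of methylsulfanyl on an aromatic carbon. Among the compounds with values here, no measured step touches the methylsulfanyl, so the evidence is indirect. Exchanges of a different group gave an at least 4.5-fold higher number from compound 2 to compound 3 (0.65 log units; beyond the scatter) and an at least 3.1-fold higher number from compound 1 to compound 3 (0.49 log units; beyond the scatter), while a step that the limit leaves unreadable from compound 1 to compound 2 cannot be read. On the strength of those modest steps, a modest move to a higher number is expected in this assay, with an estimated 3.6-fold higher number from compound 2 to compound 4 (0.56 log units; beyond the scatter). For compound 4 the estimated value is 0.08 mg/kg, with an expected range of 0.02 mg/kg to 0.3 mg/kg.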

Compound 4, dose for half-maximal effect: > 0.1 mg/kg
Compound 4: no number, only a limit (the forecaster's own chance of this, stated with the estimate: 35%); at least 1.2-fold (0.09 log units) between middle value and limit.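

In this assay, going by these compounds alone, the methylsulfanyl on this aromatic carbon, opposite the ring nitrogen, is tested directly for the first time: hydrogen in its place gives an at least 4.5-fold higher number from compound 2 to compound 4 (0.65 log units; beyond the scatter). The larger exchange of the whole aromatic group on the amide-type nitrogen gives an at least 3.1-fold higher number from compound 1 to compound 4 (0.49 log units; beyond the scatter). Compound 4 gives only a limit, > 0.1 mg/kg, so both steps are minimum sizes.

Going by these compounds, the true size of the loss on removing the methylsulfanyl stays open. So does how an ethylsulfanyl or an amine on this carbon would compare in this assay.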